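A few compounds are considered here, and "the series" means these few. Any claim that something is new, unique, unknown or untested is made for them only; others in the source may bear on it.

Three compounds built on one shared core have been run in an ADME assay on microsomes from liver (Homo sapiens) for metabolic stability, read by LC-MS, tested at 1 uM; on this read-out lower numbers stand for slow clearance and higher numbers for fast clearance. Compound 1 `c1cc([C@H]2CC[C@]3(CC2)OOC2(O3)C3CC4CC(C3)CC2C4)ccc1OCCC1CCNCC1` returns only a limit of this assay, < 7 mL.min-1.g-1, not a number. Compound 2 `c1cc([C@H]2CC[C@]3(CC2)OOC2(O3)C3CC4CC(C3)CC2C4)ccc1OCCCNC1CCOCC1` gives 10 mL.min-1.g-1. Compound 3 `NCCS(=O)(=O)CCOc1ccc([C@H]2CC[C@]3(CC2)OOC2(O3)C3CC4CC(C3)CC2C4)cc1` gives 9 mL.min-1.g-1, which stands at the low end of the two numbers shown, with compound 2 nearest and within the scatter (a 1.1-fold lower number from compound 2 to compound 3 (0.05 log units; within the scatter)). The change to compound 4 `NC1CCN(S(=O)(=O)c2ccc([C@H]3CC[C@]4(CC3)OOC3(O4)C4CC5CC(C4)CC3C5)cc2)CC1` is (4-aminopiperidin-1-yl)sulfonyl in place of 2-((2-aminoethyl)sulfonyl)ethoxy on an aromatic carbon. The measured steps of an at least 1.4-fold higher number from compound 1 to compound 2 (0.15 log units; that floor lies within the scatter) and an at least 1.2-fold higher number from compound 1 to compound 3 (0.10 log units; that floor lies within the scatter) each swapped only the end of the chain, and both were within the scatter, so none of them bears directly on removing the chain itself. Compound 4 is therefore expected to show no step beyond the scatter, no change at the digits printed from compound 3 to compound 4 (within the scatter), with an estimate of 9 mL.min-1.g-1 and a range from 4 mL.min-1.g-1 to 20 mL.min-1.g-1.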

Compound 4, intrinsic clearance in microsomes: < 7 mL.min-1.g-1
Compound 4: no number, only a limit (the forecaster's own chance of this, stated with the estimate: 25%); at least 1.2-fold (0.10 log units) between middle value and limit.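

In this assay compound 4 returns only a limit, not a number. A sulfonyl group can therefore replace the oxygen-linked chain on the aromatic carbon, para to a large group, with no rise in the read-out: an at least 1.2-fold lower number from compound 3 to compound 4 (0.10 log units; that floor lies within the scatter), and an at least 1.4-fold lower number from compound 2 to compound 4 (0.15 log units; that floor lies within the scatter). The step from compound 1 to compound 4 cannot be read because both stand at one limit: the limit of < 7 mL.min-1.g-1 in this assay, at which 2 of the 4 values shown sit.

Going by these compounds, whether the sulfonyl link or the ring amine matters more remains open. A carbonyl link in that place, or a hydroxyl group in place of the amine, would help separate the two.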